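A few compounds are considered here, and "the series" means these few. Any claim that something is new, unique, unknown or untested is made for them only; others in the source may bear on it.

Compound 2 `O=C1Nc2ccccc2/C1=C\C(=O)c1ccccc1F` gives 8500 nM in a functional assay on NCI-H460 cells (Homo sapiens) for inhibition, read by MTT assay, with a stated time of 72 h; a higher number here means a weaker inhibitor, a lower number a stronger inhibitor. Compound 1 `CC(C)C(=O)Nc1cccc(C(=O)/C=C2/C(=O)Nc3ccccc32)c1` gives 9700 nM in this assay, so compound 2 holds the lower of the two numbers, though the gap to compound 1 lies within the usual scatter and no order between them can be read. Compound 3 `O=C1Nc2ccccc2/C1=C\C(=O)c1ccccc1Br` differs from compound 2 by bromo in place of fluoro on an aromatic carbon. Among the measured compounds shown here, no measured pair shows this change, so the step it brings is expected to be small, a 1.2-fold lower number from compound 2 to compound 3 (0.08 log units; within the scatter), likely not beyond the scatter. Compound 3 is therefore estimated at 7000 nM, with a range from 3000 nM to 18000 nM.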

Compound 3, half-maximal inhibitory concentration: 11000 nM
Compound 3: the middle estimate sits 1.6-fold (0.20 log units) below what was measured, within the range that was stated.
By their numbers in this assay, from the lowest: compounds 2, 1 and 3 (each within the scatter of the next).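

In this assay, replacing fluoro with bromo on an aromatic carbon ortho to a large group gives a 1.3-fold higher number from compound 2 to compound 3 (0.11 log units; within the scatter). Among the compounds shown here, this is the first single-place comparison, and it shows that this exchange of one halogen for another leaves no readable change at this position. Nothing measured here accounts for the size of this step.

On these data alone, whether an amine, a methoxy group or a carboxylic acid at this position would move the number beyond the scatter remains open. So does whether fluoro and bromo would stay as close on another carbon of the ring.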